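The source may hold more compounds than are shown below. What is called first, only, known or untested is meant among the compounds shown, and "the series" means these compounds.

Compound 1 `O=C(O)CCc1ccc(OCc2nc(-c3ccccc3Cl)no2)cc1` gives 1200 nM in a functional assay on CHO cells for agonist activity at Free fatty acid receptor 1 (Homo sapiens), read by FLIPR and calcium flux, in the presence of a further agent that is not named here; on this read-out lower numbers stand for an effect already at smaller amounts and higher numbers for an effect only at larger amounts of compound.
Compound 2 `O=C(O)CCc1ccc(OCc2nc(-c3ccc(F)cc3)no2)cc1` gives 680 nM in this assay.
Compound 3 `O=C(O)CCc1ccc(OCc2nc(-c3cccc(Br)c3)no2)cc1` gives 1260 nM in this assay.

Compound 3 carries the highest of these three numbers, but every gap between the three lies within the scatter, so no ordering can be read from them. Compound 4 `O=C(O)CCc1ccc(OCc2nc(-c3ccc(Cl)cc3)no2)cc1` differs from compound 3 by 4-chlorophenyl in place of 3-bromophenyl on an aromatic carbon. Among the compounds with values here, two measured steps bear on this change, both swapping one halogenated phenyl for another on the same aromatic carbon: a 1.1-fold higher number from compound 1 to compound 3 (0.02 log units; within the scatter), and a 1.9-fold higher number from compound 2 to compound 3 (0.27 log units; within the scatter). Neither moved the number beyond the scatter. The change to compound 4 is of the same kind, so the expected step is a 1.5-fold lower number from compound 3 to compound 4 (0.17 log units; within the scatter), no larger than the scatter. Compound 4 is estimated at 850 nM, within a range from 350 nM to 2100 nM.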

Compound 4, half-maximal effective concentration: 540 nM
Beside the measured number, compound 4's estimate is 1.6-fold (0.20 log units) above it, and the stated range covers the measured number.
By their numbers in this assay, from the lowest: compounds 4, 2, 1 and 3 (each within the scatter of the next, the first and the last beyond it).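

On this aromatic carbon, between two ring nitrogen atoms, one halogenated phenyl replacing another can now exceed the scatter: 4-chlorophenyl in place of 3-bromophenyl gives a 2.3-fold lower number from compound 3 to compound 4 (0.37 log units; beyond the scatter) and, with the same halogen, 4-chlorophenyl in place of 2-chlorophenyl gives a 2.2-fold lower number from compound 1 to compound 4 (0.35 log units; beyond the scatter) as the clearest sign that its place on the phenyl ring matters. Chloro in place of fluoro gives only a 1.3-fold lower number from compound 2 to compound 4 (0.10 log units; within the scatter) and so separates nothing. Nothing measured here gives a cause for these steps.

Going by these compounds, whether a 4-methoxyphenyl or an unsubstituted phenyl would keep the lower numbers stays open.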